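Compound 2 to compound 3: swapping the amide substituent

The compounds below may be only part of what the source reports. "The series", "measured", "known", "first", "only" and "open" are said of these compounds alone.

Measured in a functional assay on A549 cells (Homo sapiens) for cytotoxicity, read by MTT assay, with a stated time of 72 h; a lower number here means a stronger inhibitor, a higher number a weaker inhibitor:
- compound 1 `Cc1ccc(NC(=O)CN2CCN(c3nnc(Cc4ccncc4)c4ccccc34)CC2)c(C)c1` gives 45000 nM
- compound 2 `O=C(CN1CCN(c2nnc(Cc3ccncc3)c3ccccc23)CC1)Nc1cc(C(F)(F)F)ccc1Cl` gives 1850 nM

Compound 2 has the lower of the two numbers, which makes it the stronger inhibitor so far. Compound 3 `Cc1cccc(Cl)c1NC(=O)CN1CCN(c2nnc(Cc3ccncc3)c3ccccc23)CC1` keeps the shared core and changes one group, with 2-chloro-6-methylphenyl in place of 2-chloro-5-(trifluoromethyl)phenyl on an amide-type nitrogen. Among the measured compounds shown here, one measured step bears on this, the large 24-fold lower number from compound 1 to compound 2 (1.39 log units; beyond the scatter). Compound 3 loses the trifluoromethyl and carries a methyl, as compound 1 does, but keeps the chlorine of compound 2. A moderate rise in this assay is therefore expected, smaller than that step. The expected change is a 4.9-fold higher number from compound 2 to compound 3 (0.69 log units; beyond the scatter). For compound 3 the estimated value is 9000 nM, with an expected range of 2500 nM to 35000 nM.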

Compound 3, half-maximal inhibitory concentration: 7190 nM
The estimate for compound 3 lay 1.3-fold (0.10 log units) above the measured number; the range from low to high includes it.
By their numbers in this assay, from the lowest: compound 2; then compound 3; then compound 1.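

In this assay, a compound without trifluoromethyl can still improve on compound 1: 2-chloro-6-methylphenyl in place of 2,4-dimethylphenyl gives a 6.3-fold lower number from compound 1 to compound 3 (0.80 log units; beyond the scatter). Yet replacing 2-chloro-5-(trifluoromethyl)phenyl with that same group gives a 3.9-fold higher number from compound 2 to compound 3 (0.59 log units; beyond the scatter), so the chlorine-bearing compound 3 keeps only part of the advantage of compound 2. No supporting measurement explains either step. The compounds shown leave open how a phenyl carrying chlorine alone, or one carrying an amine or a carboxylic acid, would rank at this amide nitrogen.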